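Anilino-quinazoline ethers: permeability series, compound 4

A few compounds are considered here, and "the series" means these few. Any claim that something is new, unique, unknown or untested is made for them only; others in the source may bear on it.

In an ADME assay on Caco-2 cells (Homo sapiens) for permeability, in the apical to basolateral direction (a higher number here means that the compound crosses the layer faster, a lower number that the compound crosses the layer more slowly), compound 1 (`CNC(=O)c1cc(Oc2ccc3nc(Nc4ccccc4)ncc3c2)ccn1`) gives < 1 10^-6 cm/s, which is a limit of the assay and not a number. Compound 2 (`CCc1ccccc1Nc1ncc2cc(Oc3ccnc(C(=O)NC)c3)ccc2n1`) gives < 1 10^-6 cm/s in this assay, again a limit. Compound 3 (`CNC(=O)c1cc(Oc2ccc3nc(Nc4ccccc4Oc4ccccc4)ncc3c2)ccn1`) gives < 1 10^-6 cm/s, also a limit. All three values thus sit at the limit of < 1 10^-6 cm/s in this assay, at which 3 of the 3 values shown sit, so compound 2 stands at the limit together with the other two, and no order among them can be read. The steps a step that the two limits leave unreadable from compound 1 to compound 2, a step that the two limits leave unreadable from compound 1 to compound 3 and a step that the two limits leave unreadable from compound 2 to compound 3 are therefore all unreadable in size.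

Compound 4 (`CNC(=O)c1cc(Oc2ccc3nc(Nc4cccc(Br)c4)ncc3c2)ccn1`) is not yet measured in this assay. It differs from compound 2 by 3-bromophenyl in place of 2-ethylphenyl on a nitrogen on an aromatic ring. The measured steps that bear on this change, those from compound 1 and from compound 2, are all unreadable; none shows any exchange at this position lifting the value above the limit. Compound 4 is accordingly expected to stay near the limit, with the step that the limit leaves unreadable from compound 2 to compound 4 being small and uncertain. The estimate for compound 4 is 0.5 10^-6 cm/s, ranging from 0.1 10^-6 cm/s to 2 10^-6 cm/s.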

Compound 4, apparent permeability: < 1 10^-6 cm/s
Compound 4: only a limit was reported (the forecaster's own chance of this, stated with the estimate: 75%); the middle value does not contradict the limit.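

Compound 4, like compound 1, compound 2 and compound 3, gives only a limit in this assay, so the steps to compound 4 from compound 1 and from compound 2 cannot be read: the limit of < 1 10^-6 cm/s in this assay, at which 4 of the 4 values shown sit.

The compounds shown leave open how they rank and whether any exchange at this position gives a readable value.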